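Replacing a sulfonyl group with propylcarbamoyl

A few compounds are considered here, and "the series" means these few. Any claim that something is new, unique, unknown or untested is made for them only; others in the source may bear on it.

Measured so far in a functional assay on MDA-MB-231 cells (Homo sapiens) for antiproliferative activity, read by MTT assay, with a stated time of 48 h (a lower number here means a stronger inhibitor, a higher number a weaker inhibitor), are these compounds
- compound 1 `C=CS(=O)(=O)N1CCN(c2ncnc3sc(-c4ccc(N5CCN(C)CC5)cc4)cc23)CC1` gives 7550 nM
- compound 2 `CN1CCN(c2ccc(-c3cc4c(N5CCN(S(=O)(=O)/C=C/c6ccccc6)CC5)ncnc4s3)cc2)CC1` gives 5900 nM
- compound 3 `CN1CCN(c2ccc(-c3cc4c(N5CCN(S(=O)(=O)N6CCCCC6)CC5)ncnc4s3)cc2)CC1` gives 8130 nM

These three compounds share one core and differ only in the group on the sulfonyl sulfur. Compound 3 lies within the usual scatter of both others, so its number cannot be separated from theirs.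

Compound 4 `CCCNC(=O)N1CCN(c2ncnc3sc(-c4ccc(N5CCN(C)CC5)cc4)cc23)CC1` has not yet been measured. Its difference from compound 3 is propylcarbamoyl in place of (piperidin-1-yl)sulfonyl on an amine nitrogen in a ring and in words it puts propylcarbamoyl in place of (piperidin-1-yl)sulfonyl on an amine nitrogen in a ring.

The measured steps bear on this only in part. Swapping the group on the sulfur gave a 1.3-fold lower number from compound 1 to compound 2 (0.11 log units; within the scatter) then a 1.1-fold higher number from compound 1 to compound 3 (0.03 log units; within the scatter) and also a 1.4-fold higher number from compound 2 to compound 3 (0.14 log units; within the scatter) with each step small. For the measured compounds named here, none of them removes the sulfonyl itself, so the data hold no direct precedent for this change. With nothing pointing either way, no step beyond the scatter is expected in this assay for this swap, though the uncertainty is wide. The expected change is a 1.2-fold lower number from compound 3 to compound 4 (0.06 log units; within the scatter) as estimated here. For compound 4 the estimated value is 7000 nM within an expected range from 3000 nM to 16000 nM in this estimate.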

Compound 4, half-maximal inhibitory concentration: 8330 nM
Estimate against measurement, compound 4: 1.2-fold (0.08 log units) below, within the range that was stated.
By their numbers in this assay, from the lowest: compounds 2, 1, 3 and 4 (each within the scatter of the next).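

For the compounds shown here, at the amine nitrogen in the ring, the earlier compounds changed only the group on the sulfonyl sulfur, whereas compound 4 removes the sulfonyl altogether and puts propylcarbamoyl there, which brings in a hydrogen-bond donor and loses the six-membered ring of piperidin-1-yl. In this assay, this larger change still gives only (a 1.0-fold higher number from compound 3 to compound 4 (0.01 log units; within the scatter)), and the comparisons with the two other sulfonyl compounds, (a 1.4-fold higher number from compound 2 to compound 4 (0.15 log units; within the scatter)) and (a 1.1-fold higher number from compound 1 to compound 4 (0.04 log units; within the scatter)), also stay small, so among these four compounds a sulfonyl on this nitrogen is not needed for a number of this size. Nothing measured here explains why these different groups cannot be told apart.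

Since all four numbers lie within the scatter of one another, the compounds shown do not reveal whether the group on this nitrogen matters at all in this assay. From the compounds shown here alone, a longer chain in place of propyl, a carboxylic acid at the end of that chain, or a bare amine with neither carbonyl nor sulfonyl on the nitrogen would each test this, and how any of them would behave remains open.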